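Bromo in Place of Methoxy: What Compound 4 Might Give

This account rests on a few compounds, and the source may have more. Where it says the series, first, only, none or still open, it means among the compounds named here.

compound 1 `COc1ccc(-c2cc(C(=O)Nc3ccc(Oc4ccnc5[nH]ccc45)cc3)ncn2)cc1` 4410 nM
compound 2 `Cc1ccc(-c2ccnc(C(=O)Nc3ccc(Oc4ccnc5[nH]ccc45)c(F)c3)n2)cc1` 1150 nM
compound 3 `COc1ccc(-c2cc(C(=O)Nc3ccc(Oc4ccnc5[nH]ccc45)c(F)c3)ncn2)cc1` 4210 nM

In a functional assay on A549 cells (Homo sapiens) for cytotoxicity, read by MTT assay, with a stated time of 72 h (on this read-out higher numbers stand for weaker inhibition and lower numbers for stronger inhibition), compound 3 stands second highest of the three numbers. Compound 1 lies nearest, within the scatter, while compound 2 gives the lowest number, beyond the scatter from compound 3. Compound 4 `O=C(Nc1ccc(Oc2ccnc3[nH]ccc23)c(F)c1)c1cc(-c2ccc(Br)cc2)ncn1` differs from compound 3 by bromo in place of methoxy on an aromatic carbon, para to a large group; cut one bond further out this reads 4-methoxyphenyl to 4-bromophenyl. Within the data shown here, the only measured single step, a 1.0-fold lower number from compound 1 to compound 3 (0.02 log units; within the scatter), concerns fluoro for hydrogen and does not touch this position, so no measured step bears on the change. No move beyond the scatter is therefore expected from compound 3 to compound 4, namely a 1.1-fold lower number from compound 3 to compound 4 (0.02 log units; within the scatter). Compound 4 is estimated at 4000 nM, within 1500 nM to 12000 nM.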

Compound 4, half-maximal inhibitory concentration: 6980 nM
Estimate against measurement, compound 4: 1.7-fold (0.24 log units) below, and the stated range covers the measured number.
By their numbers in this assay, from the lowest: compound 2; then compounds 3, 1 and 4 (each within the scatter of the next).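

In this assay bromo in place of methoxy on an aromatic carbon, para to a large group, gives a 1.7-fold higher number from compound 3 to compound 4 (0.22 log units; within the scatter) and so no move beyond the scatter. Among these compounds, this is the first measured step at this position, and it shows that the methoxy can be exchanged for bromo with the two numbers staying within the scatter of each other. No measurement at hand explains this result. From the compounds shown here alone, whether an amine or a carboxylic acid at this position would also stay within the scatter remains open, as does the effect of a longer chain there.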